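The compounds below may be only part of what the source reports. "The series", "measured", "known", "first", "only" and "open" are said of these compounds alone.

Measured so far, in a functional assay on HL-60 cells (Homo sapiens) for cytotoxicity, read by luminescence and CellTiter-Glo, with a stated time of 3 days; a lower number here means a stronger inhibitor, a higher number a weaker inhibitor:
Compound 1, `COc1ccc(O)c(C(=O)Nc2ccc(C#N)cc2)c1`, gives > 10000 nM, which is a limit of the assay rather than a number.
Compound 2, `O=C(Nc1ccc(C(F)(F)F)cc1)c1ccc(Cl)cc1O`, gives 630 nM.
Compound 3, `N#Cc1ccc(NC(=O)c2c(O)cccc2F)cc1`, gives > 10000 nM, again a limit and not a number.

Compound 1 therefore stands at the edge of what this assay can report; it shares that position with compound 3, as described by the limit of > 10000 nM in this assay, at which 2 of the 3 values shown sit. Only compound 2, which carries a chloro group and a trifluoromethyl group, yields an actual number. Among the compounds with values here, no pair of these three differs in a single place, so no measured step can be drawn between them.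

Compound 4, `N#Cc1ccc(NC(=O)c2cc(Br)ccc2O)cc1`, has not yet been measured. It differs from compound 1 in one place, (bromo in place of methoxy on an aromatic carbon), the bromo sitting para to the hydroxy group. Compound 4 keeps the nitrile-bearing ring of compound 1 and compound 3, both of which sit at the limit, while taking a halogen like compound 2. A modest gain is expected, a step of an at least 3.3-fold lower number from compound 1 to compound 4 (0.52 log units; beyond the scatter) in this assay, beyond the scatter but uncertain. Compound 4 is estimated at 3000 nM, with a range from 600 nM to 10000 nM.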

Compound 4, half-maximal inhibitory concentration: 620 nM
Beside the measured number, compound 4's estimate is 4.8-fold (0.68 log units) above it; measured number inside the range.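

In this assay, the position para to a hydroxy group turns out to be sensitive: with the nitrile-bearing ring held constant, bromo in place of methoxy gives a step of an at least 16-fold lower number from compound 1 to compound 4 (1.20 log units; beyond the scatter). Compound 4 is the first compound shown with that ring to give a number rather than a limit, so this single change is enough to bring the series into the measurable range of the assay. The step is a bound and not a full size, because compound 1 stands at a limit of the assay: the limit of > 10000 nM in this assay, at which 2 of the 4 values shown sit.

Within the data shown here, the single pair cannot tell whether the change in the number belongs to the arrival of bromo or to the departure of methoxy. As far as these compounds go, what an amine or a carboxylic acid at this position would give also remains open.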